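A few compounds are considered here, and "the series" means these few. Any claim that something is new, unique, unknown or untested is made for them only; others in the source may bear on it.

Measured in an ADME assay on a cell-free system (plasma, Rattus norvegicus) for protein binding, read by LC-MS, using equilibrium dialysis, with a stated time of 4 h; a lower number here means a smaller unbound share, a higher number a larger unbound share of the compound:
Compound 1 `Cn1cc(-c2ccc(Cc3cc(C(=O)NC4CCOCC4)nc4c3ccn4C)cn2)cn1`: 0.06
Compound 2 `Cn1ccc2c(Cc3ccc(-c4nccs4)cc3)cc(C(=O)N[C@@H]3CCOC[C@H]3O)nc21`: 0.02
Compound 3 `Cn1ccc(-c2ccc(Cc3cc(C(=O)N[C@@H]4CCCC[C@H]4O)nc4c3ccn4C)cn2)n1`: 0.03

In this assay, compound 2 at 0.02 lies within the scatter of compound 3, and beyond the scatter under compound 1. Compound 4 `Cn1ccc(-c2ccc(Cc3cc(C(=O)N[C@@H]4CCOC[C@H]4O)nc4c3ccn4C)cc2)n1` differs from compound 2 in one place, with 1-methyl-1H-pyrazol-3-yl in place of 1,3-thiazol-2-yl on an aromatic carbon. Among the compounds with values here, no two measured compounds differ in only one place, so this change has no direct precedent. Compound 3 also carries a 1-methyl-1H-pyrazol-3-yl group and gives 0.03, which offers only indirect support. The expected step of a 1.3-fold higher number from compound 2 to compound 4 (0.10 log units; within the scatter) is small, with no change beyond the scatter anticipated. For compound 4 the estimated value is 0.025, with an expected range of 0.012 to 0.05.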

Compound 4, unbound fraction: 0.03
For compound 4 the middle estimate is 1.2-fold (0.08 log units) below the measured one; the measured number falls inside the stated range.
By their numbers in this assay, from the lowest: compounds 2, 3, 4 and 1 (each within the scatter of the next, the first and the last beyond it).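

In this assay, within the data shown here, the exchange of 1,3-thiazol-2-yl for 1-methyl-1H-pyrazol-3-yl on an aromatic carbon, para to a large group, gives the one direct comparison at this position: a 1.5-fold higher number from compound 2 to compound 4 (0.18 log units; within the scatter). The unbound fraction therefore does not separate these two five-membered aromatic rings here. Nothing available bears on the reason for this result. As far as these compounds go, whether a carboxylic acid or a dimethylamino group in this place would give a step beyond the scatter remains open. So does whether the same exchange would give a similar step on another scaffold.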